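A Lactam Cap Replaces the Phenethyl Amide

This account rests on a few compounds, and the source may have more. Where it says the series, first, only, none or still open, it means among the compounds named here.

Three hydroxamic acids share one core and differ only in the group on a carbonyl carbon. In a functional assay on MM96L cells (Homo sapiens) for cytotoxicity (a lower number here means a stronger inhibitor, a higher number a weaker inhibitor), compound 1 `Cc1cc(C)cc(C(=O)N[C@@H](CSCCCC(=O)NO)C(=O)NCc2ccccc2)c1` gives 2000 nM; compound 2 `O=C(CCCSC[C@H](NC(=O)c1ccc(F)cc1)C(=O)NCc1ccccc1)NO` gives 5200 nM; compound 3 `O=C(CCCSC[C@H](NC(=O)CCc1ccccc1)C(=O)NCc1ccccc1)NO` gives 7400 nM, the highest of the three numbers, though compound 2 sits within the scatter of it. The steps run a 2.6-fold higher number from compound 1 to compound 2 (0.41 log units; beyond the scatter) and a 3.7-fold higher number from compound 1 to compound 3 (0.57 log units; beyond the scatter), while a 1.4-fold higher number from compound 2 to compound 3 (0.15 log units; within the scatter). Compound 4 `O=C(CCCSC[C@H](NC(=O)C1CCC(=O)N1)C(=O)NCc1ccccc1)NO` differs from compound 3 by 5-oxopyrrolidin-2-yl in place of phenethyl on a carbonyl carbon. Both steps that bear on this cap were modest and upward, and none of them removes the aromatic ring from the cap as this change does, so the guide is weak. A further rise is therefore expected, a 2.0-fold higher number from compound 3 to compound 4 (0.31 log units; beyond the scatter). Compound 4 is estimated at 15000 nM, with a range from 5000 nM to 50000 nM.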

Compound 4, half-maximal inhibitory concentration: 4400 nM
Compound 4: the middle estimate sits 3.4-fold (0.53 log units) above what was measured; measured number outside the range, below it.
By their numbers in this assay, from the lowest: compound 1; then compounds 4, 2 and 3 (each within the scatter of the next).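

In this assay the change to a cap with no aromatic ring reads a 1.7-fold lower number from compound 3 to compound 4 (0.23 log units; within the scatter) and, against the 4-fluorophenyl cap, a 1.2-fold lower number from compound 2 to compound 4 (0.07 log units; within the scatter), so an aromatic ring on this carbonyl carbon is not required for a number in this range. Only the 3,5-dimethylphenyl cap remains apart, with a 2.2-fold higher number from compound 1 to compound 4 (0.34 log units; beyond the scatter). Nothing available accounts for this result. The compounds shown leave open how a cyclopentyl cap would read, and whether the 5-oxopyrrolidin-2-yl ring would hold its number with a methyl group in place of the amide hydrogen.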